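Benzylsulfanyl Swap in Sulfonylguanidines: Cytotoxicity Outlook

The source may hold more compounds than are shown below. What is called first, only, known or untested is meant among the compounds shown, and "the series" means these compounds.

Measured compounds:
compound 1 `Cc1cc(S(=O)(=O)/N=C(\N)n2nccc2-c2ccccc2)c(SCc2ccc(Cl)cc2)cc1Cl` — 12000 nM
compound 2 `Cc1cc(S(=O)(=O)/N=C(\N)n2nccc2-c2ccccc2)c(SCc2cccc(Cl)c2)cc1Cl` — 10000 nM
compound 3 `Cc1cc(-c2ccccc2)n(/C(N)=N/S(=O)(=O)c2cc(C)c(Cl)cc2SCc2cccc(Cl)c2)n1` — 18000 nM

In an ADME assay on HaCaT cells (Homo sapiens) for cytotoxicity, read by MTT assay, with a stated time of 72 h (a lower number here means a stronger inhibitor, a higher number a weaker inhibitor), compound 2 gives 10000 nM. Among the three numbers shown, compound 1 comes nearest to it and compound 3 lies furthest from it, and both gaps are within the scatter, so the three compounds cannot be told apart in this assay. The two steps between them are small: a 1.2-fold lower number from compound 1 to compound 2 (0.08 log units; within the scatter) and a 1.8-fold higher number from compound 2 to compound 3 (0.26 log units; within the scatter).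

Compound 4 `Cc1cc(S(=O)(=O)/N=C(\N)n2nccc2-c2ccccc2)c(SCc2ccccc2C(F)(F)F)cc1Cl` is not yet measured. It differs from compound 2 in one place: 2-(trifluoromethyl)phenyl in place of 3-chlorophenyl on a saturated chain carbon bound to a sulfur. Within the data shown here, the step that bears most directly on it is the one between compound 1 and compound 2, because a 1.2-fold lower number from compound 1 to compound 2 (0.08 log units; within the scatter) shows that moving a chlorine around the phenyl bound to the saturated chain carbon next to sulfur left the number inside the scatter. The step from compound 2 to compound 3 touches a different place on the shared core and is likewise inside the scatter. Among the measured compounds shown here, nothing measured so far speaks to a trifluoromethyl on that phenyl, so the expectation rests on the narrow spread of the three numbers.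

The estimate for compound 4 is therefore 11000 nM, with a range of 5000 nM to 25000 nM, which means an expected step of a 1.1-fold higher number from compound 2 to compound 4 (0.04 log units; within the scatter) in this assay.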

Compound 4, half-maximal inhibitory concentration: 20000 nM
Beside the measured number, compound 4's estimate is 1.8-fold (0.26 log units) below it; low and high end bracket the measured number.
By their numbers in this assay, from the lowest: compounds 2, 1, 3 and 4 (each within the scatter of the next).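

In this assay, the new result extends the picture at this position from a shift of one chlorine to an exchange of the substituent itself: 2-(trifluoromethyl)phenyl, with 10 heavy atoms and fluorine in place of chlorine, replaces the 7-atom 3-chlorophenyl on the saturated chain carbon bound to a sulfur, giving a 2.0-fold higher number from compound 2 to compound 4 (0.30 log units; within the scatter), and replaces 4-chlorophenyl, giving a 1.7-fold higher number from compound 1 to compound 4 (0.22 log units; within the scatter). Compound 4 therefore cannot be told apart from compound 2 or compound 1, so among these compounds neither the kind of substituent nor its place on the phenyl separates the numbers, although both of those differ at once in each of the two new steps. Nothing available here accounts for this outcome.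

The compounds shown leave open whether a very different group on that phenyl, such as an amine or a carboxylic acid, would move the number beyond the scatter. They also leave open what an unsubstituted phenyl would give, or a longer chain in place of the saturated chain carbon bound to a sulfur.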